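A few compounds are considered here, and "the series" means these few. Any claim that something is new, unique, unknown or untested is made for them only; others in the source may bear on it.

Compound 1 `O=C(CCC1=CCN(Cc2ccc(F)cc2)C1=O)NO` gives 4070 nM in a functional assay on HCT-15 cells (Homo sapiens) for inhibition, read by sulforhodamine B assay (on this read-out lower numbers stand for stronger inhibition of growth and higher numbers for weaker inhibition of growth), and compound 2 `O=C(CCC1=CCN(Cc2ccc(Cl)cc2)C1=O)NO` gives 4720 nM. The step of a 1.2-fold higher number from compound 1 to compound 2 (0.06 log units; within the scatter) shows that the two sit together, so compound 2 stands within the scatter of compound 1. Compound 3 `N#Cc1ccc(CN2CC=C(CCC(=O)NO)C2=O)cc1` differs from compound 2 by cyano in place of chloro on an aromatic carbon. Only the halogen swap from compound 1 to compound 2 bears on this, and it was small, so no step beyond the scatter is expected in this assay; the step of a 1.0-fold lower number from compound 2 to compound 3 (0.02 log units; within the scatter) is the estimate. Compound 3 is expected to give 4500 nM, between 2000 nM and 10000 nM.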

Compound 3, concentration for 50% growth inhibition: > 10000 nM
Compound 3 was reported as a limit; the forecaster's own chance of this, stated with the estimate: 5%; at least 2.2-fold (0.34 log units) between middle value and limit.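

Compound 3 is reported only as a limit, not as a number: the limit of > 10000 nM in this assay, at which 1 of the 3 values shown sits. On the aromatic carbon para to a large group, cyano in place of chloro gives an at least 2.1-fold higher number from compound 2 to compound 3 (0.32 log units; beyond the scatter), and cyano in place of fluoro gives an at least 2.4-fold higher number from compound 1 to compound 3 (0.39 log units; beyond the scatter). So this position is not indifferent to its group: the two halogens sit within the scatter of each other, while cyano weakens growth inhibition beyond it.

On these data alone, how far compound 3 lies past its limit stays unknown. As far as these compounds go, whether a methoxy group, an amine or a carboxylic acid at this place would also weaken growth inhibition stays open.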